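The source may hold more compounds than are shown below. What is called first, only, known or untested is meant among the compounds shown, and "the series" means these compounds.

Measured compounds:
Compound 1 `CCCCCCCCNC(=O)[C@@H](NC(=O)c1ccccc1)[C@@H](C)O` gives 111000 nM
Compound 2 `CCCCCCCCNC(=O)[C@@H](NC(=O)c1ccco1)[C@@H](C)O` gives 91800 nM
Compound 3 `CCCCCCCCCCCCNC(=O)[C@@H](NC(=O)c1ccccc1)[C@@H](C)O` gives 36600 nM

In a functional assay on MCF7 cells (Homo sapiens) for cytotoxicity, read by MTT assay, with a stated time of 48 h (on this read-out lower numbers stand for stronger inhibition and higher numbers for weaker inhibition), compound 3 stands lowest of the three numbers shown: the gap to compound 2 and the gap to compound 1 both lie beyond the scatter, the larger one being a 3.0-fold lower number from compound 1 to compound 3 (0.48 log units; beyond the scatter). Compound 4 `CCCCCCCCCCCCNC(=O)[C@@H](NC(=O)c1ccco1)[C@@H](C)O` is the next compound to be measured. It differs from compound 3 in one place: furan-2-yl in place of phenyl on a carbonyl carbon. Among the measured compounds shown here, one measured step bears directly on this change, namely a 1.2-fold lower number from compound 1 to compound 2 (0.08 log units; within the scatter), which fell within the scatter. The other step, a 3.0-fold lower number from compound 1 to compound 3 (0.48 log units; beyond the scatter), concerns the chain and not the ring, so it says nothing about the ring change itself. On that basis the step is expected to be small, a 1.1-fold lower number from compound 3 to compound 4 (0.06 log units; within the scatter), with no clear direction beyond the scatter. Compound 4 is therefore estimated at 32000 nM, with a range from 15000 nM to 70000 nM.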

Compound 4, half-maximal inhibitory concentration: 67500 nM
Beside the measured number, compound 4's estimate is 2.1-fold (0.32 log units) below it; low and high end bracket the measured number.
By their numbers in this assay, from the lowest: compounds 3, 4, 2 and 1 (each within the scatter of the next, the first and the last beyond it).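

In this assay, the change from phenyl to furan-2-yl on a carbonyl carbon can now be read on a second core, where it gives a 1.8-fold higher number from compound 3 to compound 4 (0.27 log units; within the scatter); neither reading separates the two rings, and the two readings agree within their scatter: the same change on two cores in this assay, a 1.2-fold lower number (0.08 log units; within the scatter) from compound 1 to compound 2 and a 1.8-fold higher number (0.27 log units; within the scatter) from compound 3 to compound 4, 2.2-fold (0.35 log units) apart, within the scatter of two such steps

The butyl in place of hydrogen on the saturated chain can also now be read with furan-2-yl in place, where it gives a 1.4-fold lower number from compound 2 to compound 4 (0.13 log units; within the scatter). The step beyond the scatter seen with phenyl therefore has no counterpart beyond the scatter with furan-2-yl, yet the two steps cannot be told apart: the same change on two cores in this assay, a 3.0-fold lower number (0.48 log units; beyond the scatter) from compound 1 to compound 3 and a 1.4-fold lower number (0.13 log units; within the scatter) from compound 2 to compound 4, 2.2-fold (0.35 log units) apart, within the scatter of two such steps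

From the compounds shown here alone, it remains open whether a pyridin-3-yl or cyclohexyl group on that carbonyl carbon would move the number beyond the scatter. The same question stands for a longer chain or for an amine at the chain end.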